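Thiazolo-bridged anilides: thiophene replacing chlorobenzyl

The compounds below may be only part of what the source reports. "The series", "measured", "known", "first", "only" and "open" are said of these compounds alone.

Compound 1, `Nc1cccc(-c2cn3nc(-c4cccs4)sc3n2)c1`, carries the thiophen-2-yl group but no acrylamide on the aniline. In a functional assay on CCRF-CEM cells (Homo sapiens) for inhibition, read by cell counting, with a stated time of 3 days (on this read-out lower numbers stand for stronger inhibition and higher numbers for weaker inhibition), compound 1 gives > 250000 nM, which is a limit of the assay rather than a number, as noted in the limit of > 250000 nM in this assay, at which 1 of the 2 values shown sits. Within the data shown here, compound 2, `C=C(Br)C(=O)Nc1cccc(-c2cn3nc(Cc4ccc(Cl)cc4)sc3n2)c1`, pairs the 2-bromoacrylamide with a 4-chlorobenzyl group, and in this assay compound 2 gives 3300 nM, the only numerical value in the set so far. Compound 3, `C=C(Br)C(=O)Nc1cccc(-c2cn3nc(-c4cccs4)sc3n2)c1`, keeps the acrylamide of compound 2 and differs from it by thiophen-2-yl in place of 4-chlorobenzyl on an aromatic carbon. Among the measured compounds shown here, no measured step addresses this exchange, so the expected move from compound 2 to compound 3 is small, at most a slight loss within or just beyond the scatter, a 1.5-fold higher number from compound 2 to compound 3 (0.18 log units; within the scatter). Compound 3 is therefore estimated at 5000 nM, with a range from 1500 nM to 30000 nM.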

Compound 3, half-maximal inhibitory concentration: 410 nM
For compound 3 the middle estimate is 12-fold (1.09 log units) above the measured one; measured number below the stated range.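

Thiophen-2-yl in place of 4-chlorobenzyl, on the aromatic carbon next to the ring nitrogen and the ring sulfur, gives in this assay an 8.0-fold lower number from compound 2 to compound 3 (0.91 log units; beyond the scatter). With thiophen-2-yl held fixed, (1-bromoethenyl)carbonyl in place of hydrogen on the nitrogen on the aromatic ring gives an at least 600-fold lower number from compound 1 to compound 3 (2.78 log units; beyond the scatter). That second step has only a lower bound on its size, as the value of compound 1 is a limit and not a number: the limit of > 250000 nM in this assay, at which 1 of the 3 values shown sits.

The compounds shown leave open whether the gain follows from the thiophene ring itself or from a ring set directly on the core, which a phenyl or a thiophen-2-ylmethyl group at this carbon would separate. They also leave open whether the bromine matters, which an unsubstituted acrylamide or an acetamide on the same nitrogen would test.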